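The compounds below may be only part of what the source reports. "The series", "measured", "known", "first", "only" and "open" are said of these compounds alone.

Three compounds have so far been measured in a functional assay on DU-145 cells (Homo sapiens) for inhibition, read by sulforhodamine B assay, with a stated time of 48 h, tested at 0.1 uM; on this read-out lower numbers stand for a stronger effect and higher numbers for a weaker effect at the one concentration tested:

Compound 1, `COc1cc(Cl)cc(-c2nn(-c3cccc(NC(=O)Nc4ccc(Cl)c(C(F)(F)F)c4)c3)cc2-c2ccncc2)c1`: compound 1 gives 98%
Compound 2, `COc1cc(Cl)cc(-c2nn(-c3cccc(NC(=O)Nc4cc(C(F)(F)F)cc(C(F)(F)F)c4)c3)cc2-c2ccncc2)c1`: compound 2 gives 95%
Compound 3, `COc1cc(Cl)cc(-c2nn(-c3cccc(NC(=O)Nc4ccc(Cl)c(Cl)c4)c3)cc2-c2ccncc2)c1`: compound 3 gives 97%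

Compound 3 stands second highest of the three numbers. Going by the values given here, its nearest neighbour is compound 1, and the only measured step that differs in a single place, a number 1 percentage points lower from compound 1 to compound 3 (within the scatter), is a change of chloro in place of trifluoromethyl on an aromatic carbon that lies within the scatter. Compound 2 is furthest from compound 3, yet the gap between the two values also lies within the scatter, so the three measured compounds cannot be ordered on this read-out.

The next compound, compound 4, is `COc1cc(Cl)cc(-c2nn(-c3cccc(NC(=O)Nc4cccc(C(F)(F)F)c4)c3)cc2-c2ccncc2)c1`. It differs from compound 3 in one place: 3-(trifluoromethyl)phenyl in place of 3,4-dichlorophenyl on an amide-type nitrogen. The step from compound 1 to compound 3 already swapped one halogen pattern on this aryl urea for another without any effect beyond the scatter, and compound 2, which carries two trifluoromethyl groups on the same ring, sits within the scatter of both. Among the compounds with values here, no measured step therefore suggests that the aryl substituents on the urea move the number at this concentration, and the step of a number 1 percentage points lower from compound 3 to compound 4 (within the scatter) is expected to stay within the scatter. Compound 4 is accordingly estimated at 96%, with a range from 87% to 101%.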

Compound 4, a percentage reported as activity, at one concentration (the size of the read-out at that concentration, not a potency): 99%
Beside the measured number, compound 4's estimate is 3 percentage points below it; the range from low to high includes it.
By their numbers in this assay, from the lowest: compounds 2, 3, 1 and 4 (each within the scatter of the next).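

In this assay the exchange of the whole aryl group on the amide-type nitrogen gives a number 2 percentage points higher from compound 3 to compound 4 (within the scatter) and so leaves the read-out unmoved beyond the scatter. The earlier compounds had only shown one substituent exchanged for another, whereas compound 4 also shows removal: taking a trifluoromethyl group off the ring gives a number 4 percentage points higher from compound 2 to compound 4 (within the scatter) and hydrogen in place of chloro on an aromatic carbon gives a number 1 percentage points higher from compound 1 to compound 4 (within the scatter) with neither step beyond the scatter. Losing either substituent from this ring therefore does not change the reading at this one concentration.

Going by these compounds, whether an amine or a carboxylic acid on this ring, or a longer alkyl chain in place of the aryl group on that nitrogen, would give a lower number remains open. Nothing measured here offers an account of these numbers.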